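Benzyl to cyclopropyl on an amide-type nitrogen

The source may report more compounds than this note shows. Statements on the series, on what has been measured and on what is new or still open speak of the compounds shown alone.

Measured in a functional assay on HeLa cells (Homo sapiens) for inhibition, with a stated time of 72 h; a higher number here means a weaker inhibitor, a lower number a stronger inhibitor:
- compound 1 `COC(=O)C[C@H](NC(=O)OC(C)(C)C)C(=O)N(Cc1ccccc1)C1(C(=O)NCc2ccccc2)CCN(Cc2ccccc2)CC1`: 20000 nM
- compound 2 `C=CCOC(=O)N1CCC(C(=O)NCc2ccccc2)(N(Cc2ccccc2)C(=O)[C@H](CC(=O)OC)NC(=O)OC(C)(C)C)CC1`: 107000 nM
- compound 3 `COC(=O)C[C@H](NC(=O)OC(C)(C)C)C(=O)N(Cc1ccccc1)C1(C(=O)NC(C)(C)C)CCN(Cc2ccccc2)CC1`: 21000 nM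

Compound 1 stands level with compound 3, the two being separated by a 1.1-fold higher number from compound 1 to compound 3 (0.02 log units; within the scatter). Compound 2 lies clearly apart, with a 5.4-fold higher number from compound 1 to compound 2 (0.73 log units; beyond the scatter).

Compound 4 `COC(=O)C[C@H](NC(=O)OC(C)(C)C)C(=O)N(C1CC1)C1(C(=O)NCc2ccccc2)CCN(Cc2ccccc2)CC1` has not yet been measured. It departs from compound 1 as follows: cyclopropyl in place of benzyl on an amide-type nitrogen.

Among the measured compounds shown here, no measured compound alters this particular benzyl, so the evidence is indirect. For the measured compounds named here, the closest precedent is compound 3, where tert-butyl replaced benzyl on a different amide-type nitrogen and the result was a 1.1-fold higher number from compound 1 to compound 3 (0.02 log units; within the scatter). The change in compound 2, on an amine nitrogen in a ring, gave a 5.4-fold higher number from compound 1 to compound 2 (0.73 log units; beyond the scatter) and bears on this site only loosely. A small step towards a higher number in this assay is therefore expected, possibly none beyond the scatter.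

For compound 4 the estimated value is 30000 nM, with an expected range of 12000 nM to 80000 nM. This estimate corresponds to a 1.5-fold higher number from compound 1 to compound 4 (0.18 log units; within the scatter).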

Compound 4, half-maximal inhibitory concentration: 7900 nM
The estimate for compound 4 lay 3.8-fold (0.58 log units) above the measured number; the whole stated range lies above it.
By their numbers in this assay, from the lowest: compound 4; then compounds 1 and 3 (each within the scatter of the next); then compound 2.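

In this assay, the amide-type nitrogen whose other neighbours are a carbonyl carbon and a saturated ring carbon proves responsive to its substituent: cyclopropyl in place of benzyl gives a 2.5-fold lower number from compound 1 to compound 4 (0.40 log units; beyond the scatter). This is the only change among the compounds shown that lowers the number relative to compound 1, so the benzyl at this place, with its six-membered aromatic ring, is not needed for the inhibition seen here. No available data account for the lower number.

The compounds shown leave open whether the lower number belongs to the cyclopropyl ring itself or simply to the loss of benzyl. They also leave open how a methyl, an isopropyl or a cyclobutyl group would behave on this same nitrogen.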